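Dimethylamino to pyrrolidin-1-yl: a step in the dark

The source may hold more compounds than are shown below. What is called first, only, known or untested is meant among the compounds shown, and "the series" means these compounds.

Within the data shown here, in a functional assay on the whole organism (Abdomen, strain ddY) for inhibition, with Mus musculus as the target, with stated times of 30 min and 20 min (a higher number here means that more compound is needed for the effect, a lower number that less compound is needed), compound 1 (`CCCNc1cnn(C)c(=O)c1OCC`) gives 72 mg/kg and compound 2 (`CCOc1c(N(C)C)cnn(C)c1=O`) gives 86 mg/kg, so compound 2 stands level with its only neighbour. Compound 3 (`CCOc1c(N2CCCC2)cnn(C)c1=O`) carries pyrrolidin-1-yl in place of dimethylamino on an aromatic carbon, ortho to an ethoxy group: pyrrolidin-1-yl in place of dimethylamino on an aromatic carbon. Among the measured compounds shown here, the one measured step at this place, a 1.2-fold higher number from compound 1 to compound 2 (0.08 log units; within the scatter), is small, so no change beyond the scatter is expected in this assay. The expected step is a 1.1-fold lower number from compound 2 to compound 3 (0.06 log units; within the scatter). For compound 3 the estimated value is 75 mg/kg, with an expected range of 35 mg/kg to 160 mg/kg.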

Compound 3, dose for half-maximal effect: > 100 mg/kg
Compound 3: no number, only a limit; the forecaster's own chance of this, stated with the estimate: 5%; at least 1.3-fold (0.12 log units) between middle value and limit.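

Compound 3 is the only one of the three whose reading in this assay is a limit rather than a number: the limit of > 100 mg/kg in this assay, at which 1 of the 3 values shown sits. From the compounds shown here alone, the steps are an at least 1.1-fold higher number from compound 2 to compound 3 (0.06 log units; that floor lies within the scatter) and an at least 1.3-fold higher number from compound 1 to compound 3 (0.14 log units; that floor lies within the scatter), so pyrrolidin-1-yl, the first ring at this place, gives no sign of a lower number, while the true size of either step stays unknown. Going by these compounds, it remains open how far compound 3 lies past its limit, and whether piperidin-1-yl, morpholin-4-yl or an unsubstituted amino group at this place would give a readable value.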